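Chloro for methyl on the phenyl group

The source may hold more compounds than are shown below. What is called first, only, known or untested is meant among the compounds shown, and "the series" means these compounds.

Compound 1 `CCOc1nc(C)nc2sc(-c3ccccc3)nc12` and compound 2 `CCOc1nc(C)nc2sc(-c3ccc(C)cc3)nc12` share a core and differ by a methyl on an aromatic carbon. In an assay on CHO cells for displacement of a labelled ligand from adenosine receptor A3 (Homo sapiens), read by scintillation counting, with a stated time of 120 min, tested at 1 uM (a higher number here means more inhibition at the concentration tested (going by the name of the read-out), a lower number less inhibition), compound 1 gives 6%, and compound 2 gives 5%; the step of a number 1 percentage points lower from compound 1 to compound 2 (within the scatter) lies within the scatter. Compound 2 stands at the lower of the two numbers in this assay, with compound 1 within the scatter of it. Compound 3 `CCOc1nc(C)nc2sc(-c3ccc(Cl)cc3)nc12` is not yet measured; it differs from compound 2 by chloro in place of methyl on an aromatic carbon. Within the data shown here, no measured step exchanges methyl for chloro, so only the methyl-for-hydrogen step from compound 1 to compound 2, within the scatter, bears on it, and only indirectly. Both measured values lie near the bottom of the inhibition scale, so for compound 3 no step beyond the scatter is expected in this assay. The expected step in this assay is no change at the digits printed from compound 2 to compound 3 (within the scatter). The estimate for compound 3 in this assay is 5%, range 0% to 15%.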

Compound 3, a percentage reported as inhibition, at one concentration (the size of the read-out at that concentration, not a potency): 10%
Compound 3: middle estimate off by 5 percentage points, on the low side; low and high end bracket the measured number.
By their numbers in this assay, from the lowest: compounds 2, 1 and 3 (each within the scatter of the next).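

Chloro now joins hydrogen and methyl on this aromatic carbon para to a large group. In this assay, chloro in place of methyl gives a number 5 percentage points higher from compound 2 to compound 3 (within the scatter), and chloro in place of hydrogen gives a number 4 percentage points higher from compound 1 to compound 3 (within the scatter). Hydrogen, methyl and chloro at this position are therefore not told apart at the single concentration tested, and the halogen separates from hydrogen no more clearly than methyl did. No independent evidence bears on this result.

Open, from the compounds shown here alone, is whether a group of another kind at this position, such as an amine, a carboxylic acid or a longer chain, would give a step beyond the scatter in this assay. The compounds shown also leave open whether any change elsewhere on the shared core would move the number.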